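From Compound 1 to Compound 3 in One Exchange

The source may hold more compounds than are shown below. What is called first, only, known or untested is meant among the compounds shown, and "the series" means these compounds.

Compound 1 `OC[C@H]1OC(n2cnc3c(SCc4ccccc4)nccc32)[C@H](O)[C@@H]1O` is measured in a functional assay on EL4 cells (Mus musculus) for inhibition, tested at 100 uM (a lower number here means less inhibition, a higher number more inhibition at the concentration tested (going by the name of the read-out)), and gives 30% there. Compound 2 `CN(C)c1[nH]ccc2ncnc1-2` gives 25% in this assay; the two numbers shown differ by a margin within the usual scatter, so neither compound is set apart. Compound 3 `CCCCCCNc1nccc2c1ncn2C1O[C@H](CO)[C@@H](O)[C@H]1O` has not been measured; it differs from compound 1 by hexylamino in place of benzylsulfanyl on an aromatic carbon. No step between measured compounds resembles this exchange, so nothing shown points to a shift beyond the scatter in either direction. Compound 3 is therefore expected to give 30% in this assay, with a range from 10% to 55%. The estimated step of no change at the digits printed from compound 1 to compound 3 (within the scatter) is expected to stay within the scatter.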

Compound 3, a percentage reported as inhibition, at one concentration (the size of the read-out at that concentration, not a potency): 14%
The estimate for compound 3 lay 16 percentage points above the measured number; the measured number falls inside the stated range.
By their numbers in this assay, from the lowest: compound 3; then compounds 2 and 1 (each within the scatter of the next).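

In this assay, hexylamino in place of benzylsulfanyl on this aromatic carbon next to the ring nitrogen gives a number 16 percentage points lower from compound 1 to compound 3 (beyond the scatter), which shows that the group at this position bears on the read-out. The exchange removes the carbon-only aromatic ring and the sulfur and brings in a nitrogen with a hydrogen-bond donor, all at once, and this single step does not separate these changes. Nothing measured here gives a reason for the step. Open, as far as these compounds go, is whether benzylamino, which keeps the ring, or hexylsulfanyl, which keeps the sulfur, would stand nearer compound 1 or compound 3.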